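Replacing the dichlorophenyl of compound 2 with cyclohexyl

A few compounds are considered here, and "the series" means these few. Any claim that something is new, unique, unknown or untested is made for them only; others in the source may bear on it.

Measured compounds:
compound 1 `COc1ccc(C(=O)/C(=C/c2ccc(Cl)cc2Cl)CCOC(C)=O)cc1` 34800 nM
compound 2 `COc1ccc(C(=O)/C(=C/c2ccc(Cl)cc2Cl)CN(C)C(=O)c2ccccc2)cc1` 24000 nM

Both numbers come from a functional assay on NB-4 cells (Homo sapiens) for inhibition, read by XTT assay, with a stated time of 48 h; on this read-out lower numbers stand for stronger inhibition and higher numbers for weaker inhibition. Among the compounds with values here, compound 2 stands at the lower of the two numbers, but its only neighbour is compound 1, and the change a 1.5-fold lower number from compound 1 to compound 2 (0.16 log units; within the scatter) lies within the scatter, so the two compounds cannot be told apart on these data.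

Compound 3 `COc1ccc(C(=O)/C(=C/C2CCCCC2)CN(C)C(=O)c2ccccc2)cc1` has not been measured. It differs from compound 2 in one place: cyclohexyl in place of 2,4-dichlorophenyl on a double-bonded chain carbon bound to a double-bonded chain carbon. Within the data shown here, no measured step concerns this position; the single step that exists, from compound 1 to compound 2, changes a different part of the molecule and was itself within the scatter. Nothing here therefore points to a move in either direction, and the expectation for the step of a 1.3-fold higher number from compound 2 to compound 3 (0.10 log units; within the scatter) in this assay is that it stays within the scatter, with a wide range to cover the lack of any comparable step. Compound 3 is accordingly estimated at 30000 nM, with a range from 9000 nM to 100000 nM.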

Compound 3, half-maximal inhibitory concentration: 39700 nM
Estimate against measurement, compound 3: 1.3-fold (0.12 log units) below, and the stated range covers the measured number.
By their numbers in this assay, from the lowest: compounds 2, 1 and 3 (each within the scatter of the next).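

In this assay, within the data shown here, putting cyclohexyl in place of 2,4-dichlorophenyl on a double-bonded chain carbon bound to a double-bonded chain carbon gives a 1.7-fold higher number from compound 2 to compound 3 (0.22 log units; within the scatter), the first reading at this position, and on it compound 2 and compound 3 cannot be told apart. The change removes the aromatic ring and both chlorine atoms and leaves a non-aromatic ring of carbon only, so neither the aromatic ring nor the chlorine atoms prove necessary here for a number in this range, at least with the benzoyl(methyl)amino group in place. Nothing at hand bears on why the two compounds read alike.

As far as these compounds go, what stays open is whether any group at this position can carry the number beyond the scatter in either direction, for example an unsubstituted phenyl, a pyridine ring, a longer alkyl chain, an amine or a carboxylic acid. From the compounds shown here alone, it also remains open whether the same exchange would read alike on the acetoxymethyl side chain of compound 1.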